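A few compounds are considered here, and "the series" means these few. Any claim that something is new, unique, unknown or untested is made for them only; others in the source may bear on it.

Of the compounds shown here, three built on the same core have been tested in an assay on HEK293 cells for inhibition of Steryl-sulfatase (Homo sapiens), tested at 1 uM; on this read-out lower numbers stand for a weaker effect and higher numbers for a stronger effect at the one concentration tested. Compound 1 `CCN(Cc1ccc(Br)cc1)c1cccc(C(=O)N2CCc3ccc(OS(N)(=O)=O)cc3C2)c1` gives 84.5%, compound 2 `NS(=O)(=O)Oc1ccc2c(c1)CN(C(=O)c1ccc(N(Cc3ccccc3)Cc3ccco3)cc1)CC2` gives 98.2%, and compound 3 `CCN(Cc1ccc(F)cc1)c1ccc(C(=O)N2CCc3ccc(OS(N)(=O)=O)cc3C2)cc1` gives 91.2%. Compound 1 therefore holds the lowest of the three numbers, although its gap to compound 3 lies within the usual scatter, while its gap to compound 2 lies beyond it. Compound 4 `CC(C)CCN(CCC(C)C)c1cccc(C(=O)N2CCc3ccc(OS(N)(=O)=O)cc3C2)c1` has not yet been measured in this assay. It differs from compound 1 in one place: diisopentylamino in place of (4-bromobenzyl)(ethyl)amino on an aromatic carbon. Because compound 2 reaches 98.2% and compound 3 reaches 91.2% with quite different groups on that aromatic carbon, the change is expected to cost little, and the step of a number 4.5 percentage points lower from compound 1 to compound 4 (within the scatter) is expected to stay within the scatter. Compound 4 is expected to give about 80%, most likely between 55% and 95%.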

Compound 4, a percentage reported as inhibition, at one concentration (the size of the read-out at that concentration, not a potency): 75.9%
Compound 4: the middle estimate sits 4.1 percentage points above what was measured; low and high end bracket the measured number.
By their numbers in this assay, from the lowest: compounds 4, 1, 3 and 2 (each within the scatter of the next, the first and the last beyond it).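

Putting diisopentylamino in place of (4-bromobenzyl)(ethyl)amino on this aromatic carbon gives a number 8.6 percentage points lower from compound 1 to compound 4 (within the scatter). At this position, meta to a large group, a group with no ring and no bromine can therefore stand in for one carrying a six-membered aromatic ring of carbon only, with a step that stays inside the scatter. Nothing measured on these two groups is available to explain this result.

The compounds shown all keep a substituted nitrogen on this carbon. Going by these compounds, it remains open whether a plain amino group or a carboxylic acid there would hold the inhibition at a similar level.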